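This account rests on a few compounds, and the source may have more. Where it says the series, first, only, none or still open, it means among the compounds named here.

Measured so far:
- compound 1, `O=C(Nc1cccc(-n2cc(-c3ccncc3)c(-c3ccc(Cl)c(O)c3)n2)c1)Nc1ccc(Cl)c(Cl)c1`: 7220 nM
- compound 2, `COc1cc(-c2nn(-c3cccc(NC(=O)Nc4ccc(Cl)c(C(F)(F)F)c4)c3)cc2-c2ccncc2)ccc1Cl`: 1610 nM

In a functional assay on 786-0 cells (Homo sapiens) for inhibition, read by sulforhodamine B assay, with a stated time of 48 h (a lower number here means a stronger inhibitor of growth, a higher number a weaker inhibitor of growth), compound 2 gives the lower of the two numbers; compound 1 gives the higher one, and the gap lies beyond the scatter. The two differ in more than one place, so no single step is shown between them.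

Compound 3, `O=C(Nc1cccc(-n2cc(-c3ccncc3)c(-c3ccc(Cl)c(O)c3)n2)c1)Nc1ccc(Cl)c(C(F)(F)F)c1`, differs from compound 2 by hydrogen in place of methyl on an oxygen on an aromatic ring. Within the data shown here, for this change no measured step exists. The hydroxy compound 1 stands at the weaker end, but its other difference leaves the cause open; a mild weakening is expected, within or just beyond the scatter.

For compound 3 the estimate is 3000 nM, range 1000 nM to 9000 nM, an expected step of a 1.9-fold higher number from compound 2 to compound 3 (0.27 log units; within the scatter).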

Compound 3, concentration for 50% growth inhibition: 1280 nM
Beside the measured number, compound 3's estimate is 2.3-fold (0.37 log units) above it, and the stated range covers the measured number.
By their numbers in this assay, from the lowest: compounds 3 and 2 (each within the scatter of the next); then compound 1.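

In this assay, methoxy to hydroxy on the 4-chloro-3-methoxyphenyl group gives a 1.3-fold lower number from compound 2 to compound 3 (0.10 log units; within the scatter), so with trifluoromethyl present, this change at the oxygen makes no difference beyond the scatter. Trifluoromethyl in place of chloro gives a 5.6-fold lower number from compound 1 to compound 3 (0.75 log units; beyond the scatter); of the two changes, only this one lies beyond the scatter. No data at hand explain either step.

As far as these compounds go, whether an ethoxy group on that oxygen, or an amine in its place, would keep the number stays open. So does the effect of methoxy to hydroxy with chloro in place of trifluoromethyl.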